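Swapping a Methoxy Ring for a Difluoro Ring

The source may hold more compounds than are shown below. What is called first, only, known or untested is meant among the compounds shown, and "the series" means these compounds.

Three compounds sharing one core differ only in the aromatic ring carried on a saturated chain carbon bound to an amide-type nitrogen. In a functional assay on L6 cells (Rattus norvegicus) for inhibition, read by scintillation counting, with a stated time of 3 h (on this read-out higher numbers stand for weaker inhibition and lower numbers for stronger inhibition), compound 1 `Cc1ccc(CNC(=O)c2nc(-c3ccc(F)cc3)n(CC[C@@H](O)C[C@@H](O)CC(=O)O)c2C2CC2)cc1` gives 178 nM. Compound 2 `O=C(O)C[C@H](O)C[C@H](O)CCn1c(-c2ccc(F)cc2)nc(C(=O)NCc2ccccc2F)c1C1CC1` gives 27200 nM, and compound 3 `COc1cccc(CNC(=O)c2nc(-c3ccc(F)cc3)n(CC[C@@H](O)C[C@@H](O)CC(=O)O)c2C2CC2)c1` gives 538 nM. Compound 3 thus stands second highest of the three numbers. Its distance to the others is given by a 3.0-fold higher number from compound 1 to compound 3 (0.48 log units; beyond the scatter) and by a 51-fold lower number from compound 2 to compound 3 (1.70 log units; beyond the scatter). The next step leads to compound 4 `O=C(O)C[C@H](O)C[C@H](O)CCn1c(-c2ccc(F)cc2)nc(C(=O)NCc2ccc(F)c(F)c2)c1C1CC1` through (3,4-difluorophenyl in place of 3-methoxyphenyl on a saturated chain carbon bound to an amide-type nitrogen). For the measured compounds named here, no measured pair places fluorine as compound 4 does, so the steps that bear on it do so only indirectly: a ring carrying a single fluorine is involved in a 150-fold higher number from compound 1 to compound 2 (2.18 log units; beyond the scatter), a large loss, whereas the exchange of one ring substituent for another in a 3.0-fold higher number from compound 1 to compound 3 (0.48 log units; beyond the scatter) was only modest. The expectation for compound 4 is therefore a modest weakening, a 1.9-fold higher number from compound 3 to compound 4 (0.27 log units; within the scatter), carrying wide uncertainty. Compound 4 is estimated at 1000 nM, expected to fall between 200 nM and 6000 nM.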

Compound 4, half-maximal inhibitory concentration: 2780 nM
Compound 4: the middle estimate sits 2.8-fold (0.44 log units) below what was measured, and the stated range covers the measured number.
By their numbers in this assay, from the lowest: compound 1; then compound 3; then compound 4; then compound 2.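

In this assay, the 3,4-difluorophenyl ring gives a 5.2-fold higher number from compound 3 to compound 4 (0.71 log units; beyond the scatter), so this exchange costs more than the earlier estimate suggested, yet it also gives a 9.8-fold lower number from compound 2 to compound 4 (0.99 log units; beyond the scatter), which shows that rings bearing fluorine do not all behave alike at this position. The 4-methylphenyl ring keeps the lowest number of the four, with a 16-fold higher number from compound 1 to compound 4 (1.19 log units; beyond the scatter), so adding a ring with no oxygen does not close the gap to compound 1. Nothing available explains why these rings differ.

For the compounds shown here, whether each fluorine of compound 4 counts on its own stays open, as no compound here carries just one of them in those places. Also open, from the compounds shown here alone, is how a phenyl ring bearing an amine, or a longer chain in place of the benzyl carbon, would read out.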